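Swapping a bromophenyl ring for a short branched alkene

This account rests on a few compounds, and the source may have more. Where it says the series, first, only, none or still open, it means among the compounds named here.

In an ADME assay on MT4 cells (Homo sapiens) for cytotoxicity, read by MTT assay, with a stated time of 5 days (on this read-out higher numbers stand for lower toxicity in this test and lower numbers for higher toxicity in this test), compound 2 `O=C1N(Cc2ccccc2Br)c2cccn2S(=O)(=O)N1Cc1ccccc1` gives 226000 nM and stands highest of the two numbers shown. Its nearest neighbour is compound 3 `O=C1N(Cc2cccc(Cl)c2)c2cccn2S(=O)(=O)N1Cc1cccc(F)c1` with 208000 nM, a gap that lies within the scatter. Compound 1 `O=C1N(Cc2ccccc2Br)c2cccn2S(=O)(=O)N1Cc1cccc(F)c1` reaches only a limit of the assay, > 269000 nM, in this assay.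

Compound 4 `CC(C)=CCN1C(=O)N(Cc2ccccc2)S(=O)(=O)n2cccc21` has not been measured. It differs from compound 2 by 2-methylprop-1-en-1-yl in place of 2-bromophenyl on a saturated chain carbon bound to an amide-type nitrogen in a ring.

For the measured compounds named here, two measured steps touch this series. The step of an at least 1.1-fold lower number from compound 1 to compound 2 (0.07 log units; that floor lies within the scatter) and the step of an at least 1.2-fold lower number from compound 1 to compound 3 (0.11 log units; that floor lies within the scatter) both start from a limit, so only a floor is known, and both floors lie within the scatter. The second of these changes the same place as the step to compound 4, yet swaps one aromatic group for another, whereas compound 4 carries no ring there. Going by the values given here, no measured step therefore speaks directly to this change, and the expectation is a shift no larger than the scatter, with wide uncertainty.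

Compound 4 is thus expected to give about 220000 nM in this assay, between 90000 nM and 450000 nM, which would mean a step of a 1.0-fold lower number from compound 2 to compound 4 (0.01 log units; within the scatter).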

Compound 4, half-maximal cytotoxic concentration: 226000 nM
The estimate for compound 4 lay 1.0-fold (0.01 log units) below the measured number; measured number inside the range.
By their numbers in this assay, from the lowest: compounds 3, 2 and 4 (each within the scatter of the next). At a limit, above all of these: compound 1.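

In this assay there is no change at the digits printed from compound 2 to compound 4 (within the scatter), as 2-methylprop-1-en-1-yl takes the place of 2-bromophenyl on a saturated chain carbon bound to an amide-type nitrogen in a ring. The earlier step at this place only traded one aromatic group for another and started from a limit, whereas this one gives a full number for a change that removes the aromatic ring and the bromine, and the read-out stays level. One caution is that this read-out runs up to a limit, held by compound 1: the limit of > 269000 nM in this assay, at which 1 of the 4 values shown sits.

As far as these compounds go, whether an amine or a carboxylic acid at this place, or a longer chain, would stay equally level remains open. So does whether the same swap would behave alike on compound 1, which carries a fluoro group elsewhere.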